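A few compounds are considered here, and "the series" means these few. Any claim that something is new, unique, unknown or untested is made for them only; others in the source may bear on it.

Three compounds in this series carry a measurement in a functional assay on CCRF-CEM cells (Homo sapiens) for cytotoxicity, read by MTT assay, with a stated time of 72 h; on this read-out lower numbers stand for stronger inhibition of growth and higher numbers for weaker inhibition of growth. Compound 1 `CSc1ccc(CNc2nc(SC)nc3ncccc23)cc1` gives 16800 nM in this assay, the lowest of the three numbers. Compound 2 `CCCCC[Se]c1nc(N)c2ccccc2n1` gives 68000 nM, and compound 3 `CSc1ccc(CNc2nc([Se]C)nc3ccccc23)cc1` gives 86900 nM; each of these stands higher than compound 1 by more than the usual scatter, so compound 1 is the one with the strongest inhibition of growth among those measured.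

Compound 4 `CSc1nc(NCc2ccccc2)c2cccnc2n1` has not been measured. It differs from compound 1 in one place: hydrogen in place of methylsulfanyl on an aromatic carbon. Going by the values given here, no pair of measured compounds shows this same change, so no measured step can be read across to it. The change is a small one at the edge of the molecule, and the expectation is for a modest step in this assay, most likely toward weaker inhibition of growth, and possibly none beyond the scatter. Compound 4 is therefore estimated at 26000 nM, within a range from 9000 nM to 75000 nM. That estimate corresponds to an expected step of a 1.5-fold higher number from compound 1 to compound 4 (0.19 log units; within the scatter).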

Compound 4, concentration for total growth inhibition: 98600 nM
Compound 4: middle estimate off by 3.8-fold (0.58 log units), on the low side; measured number outside the range, above it.
By their numbers in this assay, from the lowest: compound 1; then compounds 2, 3 and 4 (each within the scatter of the next).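

In this assay, hydrogen in place of methylsulfanyl gives a 5.9-fold higher number from compound 1 to compound 4 (0.77 log units; beyond the scatter), so the group on this aromatic carbon, para to a large group, is not a neutral feature of compound 1. Going by these compounds alone, this is the first step that can be read between two measured compounds differing in one place, as the earlier compounds offered no such pair. It shows that the lowest number in the set depends on the presence of methylsulfanyl at this position, but no measured information accounts for the size of the step.

On these data alone, whether a methoxy group, a chlorine atom or a longer alkylsulfanyl chain at this position would keep the number of compound 1 remains open. The compounds shown also do not tell whether the same change would give a similar step on the core of compound 3.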